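Hydroxyalkyl Triazoles: Cyclohexyl for Hexyl on the Amine Series

The source may hold more compounds than are shown below. What is called first, only, known or untested is meant among the compounds shown, and "the series" means these compounds.

Compound 1 `OC1CCCCC1n1cc(CN2CCN(c3ccccc3)CC2)nn1` and compound 2 `CCCCC(O)Cn1cc(CN2CCN(c3ccccc3)CC2)nn1` share the phenylpiperazine core, and in an assay on nucleic acid for inhibition of Nucleic Acid, read by fluorescence, tested at 100 uM (a lower number here means less inhibition, a higher number more inhibition at the concentration tested (going by the name of the read-out)), compound 1 gives 47% while compound 2 gives 47%. The change 2-hydroxycyclohexyl in place of 2-hydroxyhexyl on an aromatic nitrogen therefore made a step of no change at the digits printed from compound 2 to compound 1 (within the scatter). Compound 3 `CCCCC(O)Cn1cc(CN(CCCC)CCCC)nn1` carries the dibutylamine core instead; how its core differs from that of compound 2 is not broken down here. In this assay compound 3 gives 18%, the lowest of the three numbers and beyond the scatter from compound 1 and compound 2. Compound 4 `CCCCN(CCCC)Cc1cn(C2CCCCC2O)nn1` arises from compound 3 by the same change, (2-hydroxycyclohexyl in place of 2-hydroxyhexyl on an aromatic nitrogen). Because the step of no change at the digits printed from compound 2 to compound 1 (within the scatter) was within the scatter, the expected step from compound 3 to compound 4 is no change at the digits printed from compound 3 to compound 4 (within the scatter). Compound 4 is therefore estimated at 18%, between 5% and 32%.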

Compound 4, a percentage reported as inhibition, at one concentration (the size of the read-out at that concentration, not a potency): 32%
Compound 4: the middle estimate sits 14 percentage points below what was measured, within the range that was stated.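

In this assay, 2-hydroxycyclohexyl in place of 2-hydroxyhexyl on an aromatic nitrogen gives a number 14 percentage points higher from compound 3 to compound 4 (beyond the scatter). Set beside the earlier step, the result on the two cores does not separate: the same change on two cores in this assay, no change at the digits printed (within the scatter) from compound 2 to compound 1 and a number 14 percentage points higher (beyond the scatter) from compound 3 to compound 4, 14 percentage points apart, within the scatter of two such steps. The change can be carried between these two cores without a demonstrated core dependence, but two steps do not establish that its size is the same on both, nor say how it would behave on any other core.

The compounds shown leave open whether the hydroxyl matters, as a plain cyclohexyl on the aromatic nitrogen would test. They also leave open how a longer chain than 2-hydroxyhexyl, or a morpholine in place of the amine of compound 3, would read.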